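A few compounds are considered here, and "the series" means these few. Any claim that something is new, unique, unknown or untested is made for them only; others in the source may bear on it.

Compound 1 `CCCc1nc(-c2ccccc2)c(CNCCN2CCN(c3ccccc3Cl)CC2)o1` is built from the shared core with a piperazine-type ring whose nitrogen carries a 2-chlorophenyl group. In an assay on HEK293 cells for inhibition of Voltage-dependent T-type calcium channel subunit alpha-1G (Homo sapiens), read by fluorescence, tested at 10 uM (on this read-out lower numbers stand for less inhibition and higher numbers for more inhibition at the one concentration tested (going by the name of the read-out)), compound 1 gives 60.1%, the highest of the three numbers measured. Compound 2 `CCCc1nc(-c2ccccc2)c(CNCCCN2CCN(c3ccccc3OC)CC2)o1` gives 41%, and compound 3 `CCCc1nc(-c2ccccc2)c(CNCCCN2CCN(c3cccc(C)c3)CC2)o1` gives 47.8%; compound 1 stands beyond the scatter above both of them. The only single-change step among these three is a number 6.8 percentage points higher from compound 2 to compound 3 (within the scatter), which shows that swapping one substituted phenyl ring for another on that ring nitrogen did not move the number beyond the scatter. Going by the values given here, no single-change step connects compound 1 to compound 2 or compound 3. Compound 4 `CCCc1nc(-c2ccccc2)c(CNCCN2CCN(c3ccc(OC)cc3)CC2)o1` differs from compound 1 by 4-methoxyphenyl in place of 2-chlorophenyl on an amine nitrogen in a ring. Among the compounds with values here, compound 2, the one measured compound that carries a methoxy-bearing phenyl on this nitrogen, sits lowest at 41%, so a moderate fall is expected. The estimated step is a number 15.1 percentage points lower from compound 1 to compound 4 (beyond the scatter). Compound 4 is expected to give 45%, within the range 25% to 65%.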

Compound 4, a percentage reported as inhibition, at one concentration (the size of the read-out at that concentration, not a potency): 51.5%
The estimate for compound 4 lay 6.5 percentage points below the measured number; the measured number falls inside the stated range.
By their numbers in this assay, from the lowest: compounds 2, 3, 4 and 1 (each within the scatter of the next, the first and the last beyond it).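

In this assay, replacing 2-chlorophenyl with 4-methoxyphenyl on the amine nitrogen in the ring gives a number 8.6 percentage points lower from compound 1 to compound 4 (within the scatter). Going by these compounds alone, this is the first step at this position that starts from compound 1, and it shows that a change of both the substituent and its place on the phenyl ring can leave the number within the scatter on the chain of compound 1. Nothing measured here accounts for this result.

Going by these compounds, it remains open whether the number would hold with a carboxylic acid or an amine on that phenyl ring in place of the chlorine or the methoxy group. Also open, on these data alone, is whether the group or its place on the ring counts for more, which a 2-methoxyphenyl group on the chain of compound 1 could help to separate.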